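Working notes: from compound 1 to compound 3

The compounds below may be only part of what the source reports. "The series", "measured", "known", "first", "only" and "open" are said of these compounds alone.

Measured in a functional assay on K562 cells (Homo sapiens) for inhibition, read by trypan blue exclusion, with a stated time of 72 h; a higher number here means a weaker inhibitor, a lower number a stronger inhibitor:
- compound 1 `Cn1c(=O)c(C(=O)Nc2ccc(F)cc2F)cc2cnc(Nc3ccc4[nH]ccc4c3)nc21`: 5000 nM
- compound 2 `Cn1c(=O)c(S(=O)(=O)c2ccccc2)cc2cnc(Nc3ccc4ncccc4c3)nc21`: 100000 nM

Compound 1 holds the lower of the two numbers, and its gap to compound 2 lies beyond the scatter. Going by the values given here, these two compounds differ in more than one place, so no single-change step is available. Compound 3 `Cn1c(=O)c(C(=O)Nc2ccc(F)cc2)cc2cnc(Nc3ccc4[nH]ccc4c3)nc21` departs from compound 1 by hydrogen in place of fluoro on an aromatic carbon, with hydrogen in place of fluoro on an aromatic carbon, ortho to a large group. No step beyond the scatter is expected in this assay for this change. The estimated change is a 1.1-fold lower number from compound 1 to compound 3 (0.05 log units; within the scatter). Compound 3 is expected at 4500 nM, with an estimated range of 1500 nM to 13000 nM.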

Compound 3, half-maximal inhibitory concentration: 5000 nM
The estimate for compound 3 lay 1.1-fold (0.05 log units) below the measured number; measured number inside the range.
By their numbers in this assay, from the lowest: compounds 1 and 3 (each within the scatter of the next); then compound 2.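

In this assay the change from 2,4-difluorophenyl to 4-fluorophenyl gives no change at the digits printed from compound 1 to compound 3 (within the scatter) on the shared core. Going by these compounds alone, this is the only single-change step so far, and it shows that the fluoro ortho to a large group can give way to hydrogen without a step beyond the scatter. No measured evidence bears on the reason for this result.

As far as these compounds go, whether the remaining fluoro can also give way to hydrogen stays open, as does the outcome of placing a methoxy group or an amine at the position changed here. Compound 2 differs from compound 1 in more than one place, so the gap between them cannot be assigned to any single group.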